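A few compounds are considered here, and "the series" means these few. Any claim that something is new, unique, unknown or untested is made for them only; others in the source may bear on it.

Measured compounds:
- compound 1, `COc1ccc(/C=C/C(=O)Nc2nnc(-c3ccc(C)cc3)s2)cc1`, gives 0.66 ug/mL in a functional assay on A549 cells (Homo sapiens) for antiproliferative activity, read by MTT assay, with a stated time of 48 h; on this read-out higher numbers stand for weaker inhibition and lower numbers for stronger inhibition
- compound 2, `COc1ccc(/C=C/C(=O)Nc2nnc(-c3ccccc3)s2)cc1`, gives 0.76 ug/mL in this assay

Compound 1 has the lowest of the two numbers shown, but its only neighbour is compound 2, and the step of a 1.2-fold higher number from compound 1 to compound 2 (0.06 log units; within the scatter) lies within the scatter, so the two compounds cannot be told apart on these numbers. Compound 3, `Cc1ccc(-c2nnc(NC(=O)/C=C/c3ccc(F)cc3)s2)cc1`, has not yet been measured in this assay. It differs from compound 1 in one place: fluoro in place of methoxy on an aromatic carbon.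

Within the data shown here, the one measured step, from compound 1 to compound 2, concerns a different change, hydrogen in place of methyl on an aromatic carbon of the other ring, and it was small. Among the measured compounds shown here, no measured pair shows fluoro in place of methoxy, so there is no direct guide for the size or direction of this step. With only a small change at a single position to go on, the expectation for compound 3 is a number close to that of compound 1, with the step of a 1.4-fold higher number from compound 1 to compound 3 (0.13 log units; within the scatter) expected to stay near the scatter. Compound 3 is therefore estimated at 0.9 ug/mL in this assay, within a range from 0.35 ug/mL to 2.5 ug/mL.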

Compound 3, half-maximal inhibitory concentration: 1.23 ug/mL
Compound 3: the middle estimate sits 1.4-fold (0.14 log units) below what was measured, within the range that was stated.
By their numbers in this assay, from the lowest: compounds 1, 2 and 3 (each within the scatter of the next).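

In this assay, replacing 4-methoxyphenyl with 4-fluorophenyl gives a 1.9-fold higher number from compound 1 to compound 3 (0.27 log units; within the scatter), so compound 1 and compound 3 cannot be told apart on these numbers. Among these compounds, the earlier pair changed only the other aromatic ring, so this is the first measured change on the ring that carries the methoxy group. It shows that, on this aromatic carbon para to a large group, the methoxy group can give way to the smaller fluoro group with no change beyond the scatter, although the step sits close to the edge of that scatter. No measurement bears on why the two compounds give these numbers.

With only two groups shown at this position, it remains open what an amine, a carboxylic acid or a longer chain such as butoxy would do on the same aromatic carbon. It is also open whether the methyl group on the other ring would matter any differently with fluoro in place of methoxy, as the shown compounds do not include that pair.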